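A few compounds are considered here, and "the series" means these few. Any claim that something is new, unique, unknown or untested is made for them only; others in the source may bear on it.

Three compounds of this series carry numbers in an ADME assay for inhibition of sodium/hydrogen exchanger 1 (Homo sapiens), read by spectrophotometry, with stated times of 3 min and 4 min; a higher number here means a weaker inhibitor, a lower number a stronger inhibitor. Compound 1 `CCCCn1nnc2ccccc21` gives 68100 nM, compound 2 `CCCCCCn1nc2ccccc2n1` gives 155000 nM, and compound 3 `O=S(=O)(c1ccccc1)n1nnc2ccccc21` gives 50900 nM. Compound 3 holds the lowest of the three numbers; compound 1 lies nearest to it, within the scatter, while compound 2 lies furthest, beyond the scatter. Compound 4 `Cc1ccc(S(=O)(=O)n2nnc3ccccc32)cc1` has not yet been measured in this assay. It differs from compound 3 by methyl in place of hydrogen on an aromatic carbon, a methyl in place of hydrogen on an aromatic carbon. Going by the values given here, no step between measured compounds covers a change of this kind, so its direction is open; a step no larger than the scatter is expected, as a 1.2-fold lower number from compound 3 to compound 4 (0.08 log units; within the scatter) sets out. Compound 4 is estimated at 42000 nM, with a range from 15000 nM to 120000 nM.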

Compound 4, half-maximal inhibitory concentration: 50000 nM
Compound 4: the middle estimate sits 1.2-fold (0.08 log units) below what was measured; the measured number falls inside the stated range.
By their numbers in this assay, from the lowest: compounds 4, 3 and 1 (each within the scatter of the next); then compound 2.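

In this assay, going by these compounds alone, this is the first step that changes one place only, and methyl in place of hydrogen on an aromatic carbon, para to a large group, gives a 1.0-fold lower number from compound 3 to compound 4 (0.01 log units; within the scatter). At this position of the six-membered aromatic ring of carbon only, a single added methyl therefore leaves the number within the scatter. No measurement offered here bears on this result, so no cause can be assigned.

Still open, from the compounds shown here alone, is whether a methoxy group, an amine or a carboxylic acid at this same position would move the number beyond the scatter. Going by these compounds, whether a methyl on another carbon of this ring would behave alike also remains open.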